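A few compounds are considered here, and "the series" means these few. Any claim that something is new, unique, unknown or untested is made for them only; others in the source may bear on it.

Measured so far:
compound 1, `C=C(C)[C@@H]1CC=C(C)/C(=N/NC(=O)Nc2nnc(-c3ccc(F)cc3)o2)C1`: 300 mg/kg
compound 2, `COc1ccc(-c2nnc(NC(=O)N/N=C/C/C(C)=C\CC=C(C)C)o2)cc1`: 300 mg/kg

In a functional assay on the whole organism (strain Wistar) with Rattus norvegicus as the target, with a stated time of 4 h (a lower number here means that less compound is needed, a higher number that more compound is needed for the effect), compound 2 gives 300 mg/kg, level with compound 1 at the digits shown; the two values lie within the usual scatter and mark no order between them. Compound 3, `CC(C)=CC/C=C(/C)C/C=N/NC(=O)Nc1nnc(-c2ccc([N+](=O)[O-])cc2)o1`, has not yet been measured in this assay. It differs from compound 2 by nitro in place of methoxy on an aromatic carbon. For the measured compounds named here, no step between measured compounds is available to size this change, and compound 1 and compound 2 give the same reading. The expected step of no change at the digits printed from compound 2 to compound 3 (within the scatter) is none beyond the scatter. Compound 3 is therefore estimated at 300 mg/kg, with a range from 150 mg/kg to 600 mg/kg.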

Compound 3, minimum effective dose: 300 mg/kg
Compound 3: middle estimate and measured number agree at the digits printed; measured number inside the range.
By their numbers in this assay, from the lowest: compounds 1, 2 and 3 (each within the scatter of the next).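

For the compounds shown here, replacing 4-methoxyphenyl with 4-nitrophenyl gives no change at the digits printed from compound 2 to compound 3 (within the scatter) in this assay, the first step that can be sized. At this aromatic carbon, para to a large group, nitro and methoxy are therefore not told apart by this read-out. No measured evidence bears on this result. Still open, going by these compounds, is whether an amine or a carboxylic acid on this carbon would shift the minimum effective dose. On these data alone, the effect of changing the chain while keeping the aromatic group fixed also remains unknown.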